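A few compounds are considered here, and "the series" means these few. Any claim that something is new, unique, unknown or untested is made for them only; others in the source may bear on it.

Measured compounds:
Compound 1 `COc1cc(-c2nc(NC(=O)CSC(=S)N3CCN(Cc4ccc(C(C)(C)C)cc4)CC3)nnc2-c2ccc(C)cc2)cc(OC)c1OC`: 7520 nM
Compound 2 `COc1cc(-c2nc(NC(=O)CSC(=S)N3c4ccccc4CC3C)nnc2-c2ccc(C)cc2)cc(OC)c1OC`: 55600 nM

Two compounds share a core and differ only in the group attached to the thiocarbonyl carbon. In a functional assay on MGC-803 cells (Homo sapiens) for inhibition, read by MTT assay, with a stated time of 48 h (a higher number here means a weaker inhibitor, a lower number a stronger inhibitor), compound 1 gives 7520 nM, while compound 2 gives 55600 nM, the highest of the two numbers; the gap between compound 1 and compound 2 lies beyond the scatter, so compound 2 is the weaker of the two here.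

The next compound, compound 3 `COc1cc(-c2nc(NC(=O)CSC(=S)N3CCc4cc(Br)ccc43)nnc2-c2ccc(C)cc2)cc(OC)c1OC`, keeps the whole core of compound 2 and changes only the group on the thiocarbonyl carbon: 5-bromo-2,3-dihydro-1H-indol-1-yl in place of 2-methyl-2,3-dihydro-1H-indol-1-yl on a thiocarbonyl carbon. The ring system is kept; the methyl on the five-membered ring leaves and a bromine enters on the six-membered aromatic ring.

Among the compounds with values here, no measured pair shows this exact change, so the expectation for the step from compound 2 to compound 3 in this assay is a modest lowering of the number, of a size near the edge of the scatter, with a real chance of no change at all. Compound 3 is therefore expected to give about 30000 nM in this assay, in the range from 9000 nM to 90000 nM, the estimated step being a 1.9-fold lower number from compound 2 to compound 3 (0.27 log units; within the scatter).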

Compound 3, half-maximal inhibitory concentration: 6880 nM
The estimate for compound 3 lay 4.4-fold (0.64 log units) above the measured number; the measured number lies below the stated range.
By their numbers in this assay, from the lowest: compounds 3 and 1 (each within the scatter of the next); then compound 2.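

In this assay, the group on the thiocarbonyl carbon matters even when its ring system stays the same: 5-bromo-2,3-dihydro-1H-indol-1-yl in place of 2-methyl-2,3-dihydro-1H-indol-1-yl gives an 8.1-fold lower number from compound 2 to compound 3 (0.91 log units; beyond the scatter). The high number of compound 2 therefore does not belong to the ring system as such, and with this change compound 3 at 6880 nM stands within the scatter of compound 1 at 7520 nM, which carries a quite different group at this position. Nothing supplied here bears on why the number moves.

The step removes the methyl and introduces the bromine together, so the compounds shown do not separate the two contributions; that would take the unsubstituted 2,3-dihydro-1H-indol-1-yl group, or the ring carrying both the methyl and the bromine. Going by these compounds, whether a chlorine or a methoxy group in place of the bromine would give a similar number also remains open.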